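A few compounds are considered here, and "the series" means these few. Any claim that something is new, unique, unknown or untested is made for them only; others in the source may bear on it.

Compound 2 `O=[N+]([O-])c1ccc(/C=N/c2sc3c(c2-c2nc4ccccc4s2)CCCC3)cc1` gives 454 ug/mL in an ADME assay on HepG2 cells (Homo sapiens) for cytotoxicity, read by MTT assay, with a stated time of 72 h; a higher number here means that more compound is tolerated, a lower number that less compound is tolerated; compound 1 `Clc1ccc(/C=N/c2sc3c(c2-c2nc4ccccc4s2)CCCC3)cc1` gives 397 ug/mL in this assay, and the two values sit within the scatter of each other, so no order can be read between them. Going by the values given here, the only measured step, a 1.1-fold higher number from compound 1 to compound 2 (0.06 log units; within the scatter), stays within the scatter. Compound 3 `C(=C/c1ccccc1)\C=N\c1sc2c(c1-c1nc3ccccc3s1)CCCC2` differs from compound 2 by 2-phenylethenyl in place of 4-nitrophenyl on a carbon with a double bond to nitrogen. That measured step does not bear directly on this change: it swapped one substituent on the aromatic ring, whereas here the whole 4-nitrophenyl group is exchanged for 2-phenylethenyl. Among the compounds with values here, the two measured compounds, differing only in the group on that carbon, gave numbers within the scatter of each other, which is the sole guide available. Compound 3 is expected to give about 430 ug/mL in this assay, within 220 ug/mL to 800 ug/mL. As far as these compounds go, the step of a 1.1-fold lower number from compound 2 to compound 3 (0.02 log units; within the scatter) is thus estimated to stay within the scatter, with a wide range because the change itself is untested.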

Compound 3, half-maximal cytotoxic concentration: 467 ug/mL
The estimate for compound 3 lay 1.1-fold (0.04 log units) below the measured number; measured number inside the range.
By their numbers in this assay, from the lowest: compounds 1, 2 and 3 (each within the scatter of the next).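

In this assay, the change on the carbon with a double bond to nitrogen gives a 1.0-fold higher number from compound 2 to compound 3 (0.01 log units; within the scatter) and a 1.2-fold higher number from compound 1 to compound 3 (0.07 log units; within the scatter), both within the scatter. The earlier pair varied only a substituent on the phenyl ring, whereas these steps replace the whole group with 2-phenylethenyl, a group of carbon only, and the numbers still cannot be ordered. Nothing at hand accounts for this lack of separation.

As far as these compounds go, it remains open whether an amine or a carboxylic acid in the group at this place, or a saturated alkyl chain in place of 2-phenylethenyl, would take the number beyond the scatter. From the compounds shown here alone, all three compounds share the same core, so what changes in that core would do also remains open.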